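Extending the Aryl Ether of a Piperidine Urea Antagonist

A few compounds are considered here, and "the series" means these few. Any claim that something is new, unique, unknown or untested is made for them only; others in the source may bear on it.

Compound 1, `CC1(C)[C@H]2CC=C(CN3CCC(NC(=O)Nc4ccccc4)CC3)[C@@H]1C2`: 2000 nM in a functional assay on CHO cells for antagonist activity at C-X-C chemokine receptor type 3 (Homo sapiens), read by GTPgammaS binding; a lower number here means a stronger inhibitor, a higher number a weaker inhibitor
Compound 2, `CC1(C)[C@H]2CC=C(CN3CCC(NC(=O)Nc4cccc(OC(F)(F)F)c4)CC3)[C@@H]1C2`: 31 nM in this assay

For the measured compounds named here, of the two measured compounds, compound 2 has the lower number in this assay; its only neighbour is compound 1, and the step of a 65-fold lower number from compound 1 to compound 2 (1.81 log units; beyond the scatter) lies well beyond the scatter. That single step is the whole of the measured background: it shows that the aromatic position carrying the trifluoromethoxy group tolerates, and indeed rewards, a substituent there, but it says nothing about what kind of substituent is preferred.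

Compound 3, `CC1(C)[C@H]2CC=C(CN3CCC(NC(=O)Nc4cccc(OC5CCOCC5)c4)CC3)[C@@H]1C2`, keeps the ether oxygen of compound 2 and changes what sits on it: oxan-4-yl in place of trifluoromethyl on an oxygen on an aromatic ring. Going by the values given here, no measured pair reports this kind of exchange, so the expectation rests on compound 2 alone together with the fact that the unsubstituted compound 1 gives 2000 nM. Because a 65-fold lower number from compound 1 to compound 2 (1.81 log units; beyond the scatter) was large, a return to that weaker level is possible, yet the position remains occupied in compound 3. The step of a 2.6-fold higher number from compound 2 to compound 3 (0.41 log units; beyond the scatter) is therefore expected to be modest, with a wide range. Compound 3 is estimated at 80 nM, between 15 nM and 400 nM.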

Compound 3, inhibition constant: 191 nM
The estimate for compound 3 lay 2.4-fold (0.38 log units) below the measured number; the range from low to high includes it.
By their numbers in this assay, from the lowest: compound 2; then compound 3; then compound 1.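

In this assay the ether oxygen alone does not set the level: with that oxygen held in place, oxan-4-yl in place of trifluoromethyl gives a 6.2-fold higher number from compound 2 to compound 3 (0.79 log units; beyond the scatter) and so shows that the group carried on the oxygen matters. The position nevertheless accepts a six-membered non-aromatic ring with 1 hetero atom and keeps a real part of the gain over the unsubstituted core, with a 10-fold lower number from compound 1 to compound 3 (1.02 log units; beyond the scatter) showing that the (oxan-4-yl)oxy group still stands well clear of hydrogen there. The compounds offer no independent measurement that could explain why the trifluoromethoxy group gives the lower number of the two ethers.

As far as these compounds go, what remains open is whether the ring itself or its oxygen decides the level, since a cyclohexyl ether or a piperidin-4-yl ether with a ring amine would separate these two possibilities. From the compounds shown here alone, it is also open whether an open chain on the same oxygen, such as a 2-methoxyethyl group, or a plain methyl or ethyl group, would fall nearer compound 2 or nearer compound 3 in this series.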